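Swapping fluoro for hydroxy on compound 3

The source may report more compounds than this note shows. Statements on the series, on what has been measured and on what is new or still open speak of the compounds shown alone.

For the measured compounds named here, in a functional assay on HepG2 cells (Homo sapiens) for antiproliferative activity, read by MTT assay, with a stated time of 48 h (on this read-out lower numbers stand for stronger inhibition and higher numbers for weaker inhibition), compound 3 (`COc1ccc(N(C)c2cc(C)nc(C)n2)cc1F`) gives 2060 nM, the higher of the two exact numbers so far, while compound 1 (`COc1ccc(N(C)c2ccnc(Cl)n2)cc1O`) gives 464 nM. Compound 2 (`COc1ccc(N(C)c2ccnc(Cl)n2)cc1OCCCC[Se]C#N`) gives > 10000 nM, which is a limit of the assay. Compound 4 (`COc1ccc(N(C)c2cc(C)nc(C)n2)cc1O`) carries hydroxy in place of fluoro on an aromatic carbon, ortho to a methoxy group: hydroxy in place of fluoro on an aromatic carbon. Going by the values given here, the only measured step at such an oxygen is large: an at least 21-fold higher number from compound 1 to compound 2 (1.33 log units; beyond the scatter), with a chain replacing the hydrogen atom. Compound 1, with its free hydroxy at 464 nM, suggests a lower number, although it also differs from compound 4 elsewhere. The expected change in this assay is moderate: a 2.6-fold lower number from compound 3 to compound 4 (0.41 log units; beyond the scatter). The estimated value for compound 4 is 800 nM, within an expected range of 200 nM to 3000 nM.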

Compound 4, half-maximal inhibitory concentration: 112 nM
Estimate against measurement, compound 4: 7.1-fold (0.85 log units) above; the measured number lies below the stated range.
By their numbers in this assay, from the lowest: compound 4; then compound 1; then compound 3. At a limit, above all of these: compound 2.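

In this assay, hydroxy in place of fluoro on an aromatic carbon, ortho to a methoxy group, gives an 18-fold lower number from compound 3 to compound 4 (1.26 log units; beyond the scatter) and so isolates this position with the rest of the molecule unchanged. For the compounds shown here, the only earlier step here replaced the hydroxy hydrogen with a chain, whereas this one compares the free hydroxy directly with fluoro. Nothing measured here gives a reason for the step.

Going by these compounds, an amine or a carboxylic acid on this carbon remains open. So does whether fluoro would raise the number as much on the core of compound 1.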